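A few compounds are considered here, and "the series" means these few. Any claim that something is new, unique, unknown or untested is made for them only; others in the source may bear on it.

Series notes. Compound 1 `CCCNC(=O)[C@@H]1C[C@H]2CCC[C@@H](C1)[C@@H]2NC(=O)c1cc2scnc2n1Cc1ccc(OC)cc1` and compound 2 `CCCNC(=O)[C@@H]1C[C@H]2CCC[C@@H](C1)[C@@H]2NC(=O)c1cc2sc(Br)nc2n1Cc1ccc(OC)cc1` share one core, compound 3 `CCCNC(=O)C1CCN(C(=O)c2cccn2Cc2ccc(OC)cc2)CC1` and compound 4 `CCCNC(=O)C1CCN(C(=O)c2cc(Br)cn2Cc2ccc(OC)cc2)CC1` another. The difference between the two cores is not broken down here. In an ADME assay on HEK-293T cells (Homo sapiens) for cytotoxicity, read by luminescence and CellTiter-Glo, with a stated time of 24 h (a higher number here means that more compound is tolerated, a lower number that less compound is tolerated), compound 1 gives > 25000 nM, which is a limit of the assay. In this assay compound 2 gives > 100000 nM, also a limit. The change bromo in place of hydrogen on an aromatic carbon therefore yields a step that the two limits leave unreadable from compound 1 to compound 2. In this assay compound 3 gives > 100000 nM, again a limit. Compound 4 carries the same kind of change, (bromo in place of hydrogen on an aromatic carbon), but the surroundings differ: in compound 2 the carbon is next to the ring nitrogen and next to the ring sulfur in a fused system, whereas in compound 4 it lies two ring bonds from the ring nitrogen, two from the ring atom that bears a 4-methoxybenzyl group and two from the ring atom that bears a large group. Two values sit at the limit of > 100000 nM in this assay, at which 2 of the 3 values shown sit, and one at the limit of > 25000 nM in this assay, at which 1 of the 3 values shown sits, so no cytotoxicity has been resolved in the set. The expected step from compound 3 to compound 4 is a number no higher from compound 3 to compound 4 (the limit leaves the size open), essentially flat. Compound 4 is expected at 100000 nM, most likely reported only as a limit.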

Compound 4, half-maximal cytotoxic concentration: 55000 nM
Beside the measured number, compound 4's estimate is 1.8-fold (0.26 log units) above it; the measured number falls inside the stated range.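

In this assay, bromo in place of hydrogen on an aromatic carbon gives an at least 1.8-fold lower number from compound 3 to compound 4 (0.25 log units; that floor lies within the scatter). This shows that compound 4 has a measured number where compound 3 has only a limit, but the floor alone does not establish a real difference between them. The steps on the core of compound 1 and on the core of compound 3 cannot be compared: the step from compound 1 to compound 2 cannot be read, so nothing shows whether the change carries from one core to the other.

Open, on these data alone, is whether chloro or an amine in place of the bromo on the core of compound 3 would give a measured number. Also open, as far as these compounds go, is whether either group would do so on the core of compound 1.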